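A Chloro Added to the Core of a Weak Inhibitor

This account rests on a few compounds, and the source may have more. Where it says the series, first, only, none or still open, it means among the compounds named here.

Compound 1 `O=c1oc2ccccc2n1Cc1ccc(Cl)cc1` was tested in an assay on HeLa cells for inhibition of Indoleamine 2,3-dioxygenase 1 (Homo sapiens), with a stated time of 24 h (on this read-out higher numbers stand for weaker inhibition and lower numbers for stronger inhibition), and gives 35000 nM. Compound 2 `O=c1oc2ccc(Cl)cc2n1Cc1cccc(F)c1` gives 9750 nM in this assay. Of these two numbers, compound 1 has the higher one, and its gap to compound 2 lies beyond the scatter, so compound 2 is the stronger of the pair; the two structures differ in more than one place, so their values alone say no more than that. Compound 3 `O=c1oc2ccc(Cl)cc2n1Cc1ccc(Cl)cc1` has not yet been measured. It differs from compound 1 by chloro in place of hydrogen on an aromatic carbon. For the measured compounds named here, compound 2 carries a chloro on the shared core as well, but with a differently substituted benzyl group, so no single measured step isolates this change. Because compound 2 sits at 9750 nM while compound 1 sits at 35000 nM, the expected step is a 2.3-fold lower number from compound 1 to compound 3 (0.37 log units; beyond the scatter), a moderate lowering of the number. Compound 3 is therefore estimated at 15000 nM, with a range from 5000 nM to 45000 nM.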

Compound 3, half-maximal inhibitory concentration: 6080 nM
The estimate for compound 3 lay 2.5-fold (0.39 log units) above the measured number; measured number inside the range.
By their numbers in this assay, from the lowest: compounds 3 and 2 (each within the scatter of the next); then compound 1.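

For the compounds shown here, with the benzyl group left unchanged, chloro in place of hydrogen on the shared core brings a 5.8-fold lower number from compound 1 to compound 3 (0.76 log units; beyond the scatter) in this assay and gives the first clean reading of this change, which compound 1 and compound 2 could not give since they differ in more than one place. The step lies beyond the usual scatter, so a single chlorine on this aromatic carbon, meta to a fused ring and para to a fused ring, is enough to shift the number on its own. Nothing measured here speaks to the reason for the shift.

From the compounds shown here alone, it remains open whether chloro is unusual at this carbon, or whether a methyl, a methoxy group or a carboxylic acid there would shift the number as well. Going by these compounds, the effect of chloro on the other carbons of this ring also remains open.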